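The source may hold more compounds than are shown below. What is called first, only, known or untested is meant among the compounds shown, and "the series" means these compounds.

Compound 1 `CCCC(=O)Nc1ccc(S(=O)(=O)Oc2ccccc2I)cc1` and compound 2 `CCCCCC(=O)Nc1ccc(S(=O)(=O)Oc2ccccc2I)cc1` share one core and differ by ethyl in place of hydrogen on a saturated chain carbon, three bonds along the chain from a carbonyl carbon. In a functional assay on M21 cells (Homo sapiens) for antiproliferative activity, read by sulforhodamine B assay, with a stated time of 48 h (a lower number here means a stronger inhibitor, a higher number a weaker inhibitor), compound 1 gives 9000 nM, and compound 2 gives 11000 nM. Between them the change gives a 1.2-fold higher number from compound 1 to compound 2 (0.09 log units; within the scatter). Compound 3 `CCCNC(=O)Nc1ccc(S(=O)(=O)Oc2ccccc2C(C)C)cc1` rests on a different core; how its core differs from that of compound 1 is not broken down here. In this assay compound 3 gives 5100 nM. Compound 4 `CCCCCNC(=O)Nc1ccc(S(=O)(=O)Oc2ccccc2C(C)C)cc1` differs from compound 3 by ethyl in place of hydrogen on a saturated chain carbon, three bonds along the chain from an amide-type nitrogen. Among the compounds with values here, this is the same kind of change as the one between compound 1 and compound 2, not the same: there the place lies on a saturated chain carbon three bonds along the chain from a carbonyl carbon, here on a saturated chain carbon three bonds along the chain from an amide-type nitrogen. Because a 1.2-fold higher number from compound 1 to compound 2 (0.09 log units; within the scatter) stayed within the scatter, a similarly small step is expected here, a 1.2-fold higher number from compound 3 to compound 4 (0.07 log units; within the scatter). Compound 4 is therefore expected to give 6000 nM in this assay, with a likely range from 3000 nM to 12000 nM.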

Compound 4, half-maximal inhibitory concentration: 4600 nM
Estimate against measurement, compound 4: 1.3-fold (0.12 log units) above, and the stated range covers the measured number.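

In this assay, the same ethyl in place of hydrogen gives a 1.1-fold lower number from compound 3 to compound 4 (0.04 log units; within the scatter), and set beside the earlier step, the change reads alike on the two cores: the same change on two cores in this assay, a 1.2-fold higher number (0.09 log units; within the scatter) from compound 1 to compound 2 and a 1.1-fold lower number (0.04 log units; within the scatter) from compound 3 to compound 4, 1.4-fold (0.13 log units) apart, within the scatter of two such steps. For these two pairs, then, adding the ethyl leaves the number within the scatter on both cores, so the small step carries over from one core to the other. This does not show that the change would stay as small on any other core, and as neither step rises above the scatter, the pairs cannot show whether a larger effect would carry over.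

From the compounds shown here alone, it remains open whether a longer chain, or a chain ending in an amine or a carboxylic acid, would move the number beyond the scatter on either core.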